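Notes on a carboxamide-for-hydroxyl change in the series

This account rests on a few compounds, and the source may have more. Where it says the series, first, only, none or still open, it means among the compounds named here.

Of the compounds shown here, three have been measured in an assay on isolated protein for inhibition of protein kinase C delta type (Homo sapiens), read by TR-FRET, with a stated time of 2 h; a lower number here means a stronger inhibitor, a higher number a weaker inhibitor. Compound 1 `N#Cc1cnc(NCc2ccccc2C(F)(F)F)cc1N[C@H]1CC[C@@H](O)CC1` gives 4500 nM, the highest of the three numbers. Compound 2 `N#Cc1cnc(NCc2cnccc2C(F)(F)F)cc1NC[C@H]1CC[C@@H](O)CC1` gives 500 nM and compound 3 `N#Cc1cnc(NCc2cnccc2C(F)(F)F)cc1NC[C@H]1CC[C@H](O)CC1` gives 2000 nM; the step of a 4.0-fold higher number from compound 2 to compound 3 (0.60 log units; beyond the scatter) rests only on (the fact that compounds 2 and 3 differ only in the configuration as drawn). Compound 4 `N#Cc1cnc(NCc2ccccc2C(F)(F)F)cc1N[C@H]1C[C@@H](C(N)=O)C1` is compound 1 with 3-carbamoylcyclobutyl in place of 4-hydroxycyclohexyl on a nitrogen on an aromatic ring. Within the data shown here, no measured pair isolates this change: the single step on record is the mirror-image pair, which keeps the 4-hydroxycyclohexyl and its nitrogen on the aromatic ring untouched, so it does not bear on the exchange of a six-membered ring bearing a hydroxyl for a four-membered ring bearing a carboxamide. The expected step of a 1.1-fold lower number from compound 1 to compound 4 (0.05 log units; within the scatter) is therefore set near zero, with wide uncertainty in both directions. For compound 4 the estimate is 4000 nM, with a range of 700 nM to 20000 nM.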

Compound 4, half-maximal inhibitory concentration: 4200 nM
Compound 4: the middle estimate sits 1.1-fold (0.02 log units) below what was measured; the range from low to high includes it.
By their numbers in this assay, from the lowest: compound 2; then compound 3; then compounds 4 and 1 (each within the scatter of the next).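

In this assay, 3-carbamoylcyclobutyl in place of 4-hydroxycyclohexyl on a nitrogen on an aromatic ring gives a 1.1-fold lower number from compound 1 to compound 4 (0.03 log units; within the scatter) on the core of compound 1. At this position, therefore, a four-membered ring bearing a carboxamide and a six-membered ring bearing a hydroxyl cannot be told apart in this assay. Nothing on record bears on why the step is so small.

Ring size and the hydroxyl-to-carboxamide exchange change together here, so neither can be read alone. On these data alone, whether a carboxylic acid or an amine on the four-membered ring would also leave the number level remains open.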